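Methoxy for nitro on a shared oxadiazole-ketone core

A few compounds are considered here, and "the series" means these few. Any claim that something is new, unique, unknown or untested is made for them only; others in the source may bear on it.

Measured so far:
Compound 1 `Cc1ccc(C(=O)CCc2nnc(-c3ccc(Cl)cc3)o2)cc1` gives 81.5%.
Compound 2 `Cc1ccc(C(=O)CCc2nnc(-c3ccc([N+](=O)[O-])cc3)o2)cc1` gives 60.5%.

Both numbers come from a functional assay on the whole organism (strain Wistar) for inhibition, with Rattus norvegicus as the target, with stated times of 30 min and 3 h, at a dose of 20 mg/kg by the oral route; a lower number here means less inhibition, a higher number more inhibition at the dose given (going by the name of the read-out). Within the data shown here, on these two numbers compound 2 stands lowest; its only neighbour is compound 1, which gives a number higher by the step of a number 21 percentage points lower from compound 1 to compound 2 (beyond the scatter) when read the other way round. Among the measured compounds shown here, that step, a modest fall beyond the scatter, is the one measured change on this core: the swap of the group on the outer aromatic ring.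

Compound 3 `COc1ccc(-c2nnc(CCC(=O)c3ccc(C)cc3)o2)cc1` is not yet measured. It differs from compound 2 in one place: methoxy in place of nitro on an aromatic carbon. For the measured compounds named here, no measured step tells how a methoxy group behaves here; the only step, from chloro to nitro, shows that the group in this place can move the inhibition by a modest amount. With nothing measured for methoxy itself, the direction is open, so the estimate for compound 3 is placed between the two measured values with a wide range: compound 3 is expected to give 70%, between 50% and 88%, meaning an expected step of a number 9.5 percentage points higher from compound 2 to compound 3 (within the scatter).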

Compound 3, a percentage reported as inhibition, in the whole organism at one dose (the size of the read-out at that dose, not a potency): 89.5%
The estimate for compound 3 lay 19.5 percentage points below the measured number; the measured number lies above the stated range.
By their numbers in this assay, from the lowest: compound 2; then compounds 1 and 3 (each within the scatter of the next).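

In this assay, among these compounds, replacing nitro with methoxy gives a number 29 percentage points higher from compound 2 to compound 3 (beyond the scatter), so this position can raise the inhibition as well as lower it, and the single chloro-to-nitro step could not show that. Methoxy in place of chloro gives a number 8 percentage points higher from compound 1 to compound 3 (within the scatter), so these two different groups cannot be told apart in this test, while compound 2, with its nitro group, stands apart from both, with a number 21 percentage points lower from compound 1 to compound 2 (beyond the scatter) as its other step. Nothing shown here explains why nitro alone stands apart, and the three compounds offer no measurement that would link the inhibition to any property of these groups.

On these data alone, it remains open whether an amine or a carboxylic acid on this aromatic carbon would stay level with chloro and methoxy or fall towards nitro. Each number also comes from a single dose and so gives no potency, and the methyl group on the other aromatic ring and the ketone chain of the shared core stay unchanged across all three compounds, leaving their part in the inhibition unknown.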